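Oxime ether series: cyano substitution on the arylpiperazine

A few compounds are considered here, and "the series" means these few. Any claim that something is new, unique, unknown or untested is made for them only; others in the source may bear on it.

Measured compounds:
- compound 1, `O/N=C(/CCN1CCN(c2ccccn2)CC1)c1ccccc1`, 21.7 nM
- compound 2, `CCO/N=C(\CCN1CCN(c2ccccc2)CC1)c1ccccc1`, 109 nM

The series is read in a functional assay on HEK293 cells with D(4) dopamine receptor (Homo sapiens) as the target, read by FLIPR; on this read-out lower numbers stand for an effect already at smaller amounts and higher numbers for an effect only at larger amounts of compound. Going by the values given here, of the two numbers in hand, compound 2 stands with the highest, and its only neighbour is compound 1, whose number is the lower of the pair by a margin that lies beyond the scatter. Among the compounds with values here, no single-point step between the two measured compounds can be drawn, since they differ in more than one place; their two values are all that can be said of them.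

Compound 3, `CCO/N=C(\CCN1CCN(c2ccccc2C#N)CC1)c1ccccc1`, is not yet measured. It follows compound 2 directly: cyano in place of hydrogen on an aromatic carbon, that is, phenyl to 2-cyanophenyl, with the new group ortho to a large group. Within the data shown here, no measured pair in this set shows the effect of such a change, so no computed step is available in this assay. The expectation is a step of modest size, more likely toward a lower number than a higher one, but possibly within the scatter. Compound 3 is therefore estimated at 80 nM, with a range from 25 nM to 300 nM, which as an expected step reads a 1.4-fold lower number from compound 2 to compound 3 (0.13 log units; within the scatter).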

Compound 3, half-maximal effective concentration: 48.7 nM
Estimate against measurement, compound 3: 1.6-fold (0.22 log units) above, and the stated range covers the measured number.
By their numbers in this assay, from the lowest: compound 1; then compound 3; then compound 2.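

In this assay, going by these compounds alone, the phenyl to 2-cyanophenyl change gives the first step that can be tied to a single place: a 2.2-fold lower number from compound 2 to compound 3 (0.35 log units; beyond the scatter). A cyano group on an aromatic carbon, ortho to a large group, is therefore accepted on the core of compound 2 and brings a modest move to a lower number, beyond the scatter, whereas compound 1 and compound 2 differ in more than one place and assign nothing to any single part of the structure. Nothing on hand accounts for this step, which remains an observation on one pair.

Still open, on these data alone, is whether the step is particular to the cyano group or would also appear with another group in the same place, such as fluoro, methoxy, a carboxylic acid or an amine. Also open, as far as these compounds go, is whether cyano in place of hydrogen gives a step of similar size on the core of compound 1, or at another carbon of the same aromatic ring.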